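A few compounds are considered here, and "the series" means these few. Any claim that something is new, unique, unknown or untested is made for them only; others in the source may bear on it.

Working notes on the series in a functional assay on HL-60 cells (Homo sapiens) for antiproliferative activity, read by sulforhodamine B assay, with a stated time of 72 h; a lower number here means a stronger inhibitor, a higher number a weaker inhibitor. Compound 1 `NC(=S)N/N=C/c1ccc2cccnc2n1` reaches only the assay limit: in this assay compound 1 gives > 100000 nM, which is a limit and not a number, the line the limit of > 100000 nM in this assay, at which 1 of the 3 values shown sits, applying here. Of the two numbers that remain, compound 2 `S=C(N/N=C/c1ccc2ccccc2n1)Nc1cccc(Br)c1` gives the higher one, 53800 nM in this assay, while compound 3 `CN(C)C(=S)N/N=C/c1nc2ccccc2s1`, built on a different core, gives the lower one, 3680 nM; the gap between the two lies beyond the scatter, so compound 2 is the weaker of the two measured inhibitors. Compound 4 `S=C(N/N=C/c1ccc2ccccc2n1)Nc1ccccc1` differs from compound 2 in one place: hydrogen in place of bromo on an aromatic carbon. Within the data shown here, no pair among the measured compounds carries this kind of change, so nothing bounds it directly. A single heavy atom leaves an outer ring; the expected step is a 1.4-fold higher number from compound 2 to compound 4 (0.14 log units; within the scatter), a modest loss at most, possibly none beyond the scatter. Compound 4 is therefore estimated at 75000 nM in this assay, with a range from 25000 nM to 200000 nM, and a real chance that only the limit is reported.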

Compound 4, half-maximal inhibitory concentration: 9130 nM
For compound 4 the middle estimate is 8.2-fold (0.91 log units) above the measured one; the whole stated range lies above it.
By their numbers in this assay, from the lowest: compound 3; then compound 4; then compound 2. At a limit, above all of these: compound 1.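

In this assay, among these compounds, the change from 3-bromophenyl to phenyl gives the first one-place step that can be read, a 5.9-fold lower number from compound 2 to compound 4 (0.77 log units; beyond the scatter), which shows that this place on the aromatic ring is not indifferent to what it carries. Of this pair, the compound with hydrogen is the stronger inhibitor, so bromo at this place is not required for the activity seen here. Compound 1 remains the only compound at a limit, which is not a number: the limit of > 100000 nM in this assay, at which 1 of the 4 values shown sits.

As far as these compounds go, whether a methoxy group, an amine or a carboxylic acid at this place would track with bromo or with hydrogen stays open. Also open, from the compounds shown here alone, is whether the same change would give a similar step on the core of compound 3.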